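Capping the Remaining Ring Nitrogen with Methoxymethyl

A few compounds are considered here, and "the series" means these few. Any claim that something is new, unique, unknown or untested is made for them only; others in the source may bear on it.

Compound 1 `COCn1c(CC(COCc2ccccc2)COCc2ccccc2)cc(=O)[nH]c1=O`: > 100000 nM
Compound 2 `COCn1c(CC(COCc2ccccc2)COCc2ccccc2)c(C)c(=O)[nH]c1=O`: 72100 nM
Compound 3 `COCn1c(=O)[nH]c(CC(COCc2ccccc2)COCc2ccccc2)c(C)c1=O`: 25600 nM

In a functional assay on SW-620 cells (Homo sapiens) for antiproliferative activity, read by MTT assay, with a stated time of 72 h (a higher number here means a weaker inhibitor, a lower number a stronger inhibitor), compound 1 reaches only the limit of the assay, > 100000 nM. Compound 2 gives 72100 nM and compound 3 gives 25600 nM, the lowest of the two numbers shown. For the measured compounds named here, the one measured step, an at least 1.3-fold lower number from compound 1 to compound 2 (0.14 log units; that floor lies within the scatter), is a methyl on an aromatic carbon, and its size rests on a limit, (the limit of > 100000 nM in this assay, at which 1 of the 3 values shown sits).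

Compound 4 `COCn1c(CC(COCc2ccccc2)COCc2ccccc2)c(C)c(=O)n(COC)c1=O` differs from compound 3 by methoxymethyl in place of hydrogen on an aromatic nitrogen. Going by the values given here, no measured step touches a ring nitrogen, so the change has no direct precedent here. Compound 4 is therefore expected to stay near compound 3, with the step of a 1.6-fold higher number from compound 3 to compound 4 (0.19 log units; within the scatter) judged uncertain in direction, and the estimate is 40000 nM within 8000 nM to 150000 nM.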

Compound 4, half-maximal inhibitory concentration: 500 nM
Beside the measured number, compound 4's estimate is 80-fold (1.90 log units) above it; the whole stated range lies above it.
By their numbers in this assay, from the lowest: compound 4; then compound 3; then compound 2. At a limit, above all of these: compound 1.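

Methoxymethyl in place of hydrogen on the remaining aromatic nitrogen gives a 51-fold lower number from compound 3 to compound 4 (1.71 log units; beyond the scatter) and a 140-fold lower number from compound 2 to compound 4 (2.16 log units; beyond the scatter) in this assay with the same change in both cases. Both steps lie beyond the scatter, so among the compounds shown, capping this ring nitrogen brings the largest drop in the number. Nothing measured here explains why this group on this nitrogen has such an effect.

Going by these compounds, whether a plain methyl, a longer chain or a carboxylic acid on that nitrogen would do the same remains open. So does whether the second methoxymethyl would work as well on compound 1, which lacks the methyl on the aromatic carbon.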